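A few compounds are considered here, and "the series" means these few. Any claim that something is new, unique, unknown or untested is made for them only; others in the source may bear on it.

In a toxicity assay on HepG2 cells (Homo sapiens) for inhibition, read by resazurin assay, with a stated time of 24 h (a higher number here means that more compound is tolerated, a lower number that less compound is tolerated), three compounds have been read, and none returns a number. Compound 1 (`O=C(NCc1ccc(F)cc1)c1ncc([N+](=O)[O-])[nH]1`) gives > 100000 nM as a limit of the assay. Compound 2 (`CNC(=O)c1ncc([N+](=O)[O-])[nH]1`) gives > 100000 nM as a limit too. Compound 3 (`NC(=O)c1nc([N+](=O)[O-])cn1Cc1ccccn1`) gives > 100000 nM as a limit again. It stands with the others at the limit of > 100000 nM in this assay, at which 3 of the 3 values shown sit, with no number to separate them. Compound 4 (`NC(=O)c1nc([N+](=O)[O-])cn1CC1CC1`) differs from compound 3 in one place, with cyclopropyl in place of pyridin-2-yl on a saturated chain carbon bound to an aromatic nitrogen. No change is expected in this assay because compound 3 gives > 100000 nM as a limit. The expected step, as estimated, is a number no higher from compound 3 to compound 4 (the limit leaves the size open) in this reading. Compound 4 is estimated at 100000 nM with an expected range from 40000 nM to 200000 nM around that figure.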

Compound 4, half-maximal cytotoxic concentration: > 100000 nM
Compound 4: no number, only a limit; the forecaster's own chance of this, stated with the estimate: 85%; the middle value sits exactly at the limit.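

No step can be read between compound 3 and compound 4, as each gives only a limit in this assay: the limit of > 100000 nM in this assay, at which 4 of the 4 values shown sit.

The compounds shown leave open at what concentration any of them affects the cells, and whether cyclopropyl in place of pyridin-2-yl changes that concentration.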